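The compounds below may be only part of what the source reports. "The series", "measured", "known", "first", "only" and "open" are said of these compounds alone.

Working notes on the series. Compound 3 `Cc1ccc(C2CNN=C2S(=O)(=O)CC2=NCCO2)cc1` and compound 1 `Cc1ccc(C2CNN=C2S(=O)(=O)CC2=NCCS2)cc1` share one core; compound 2 `COc1ccc(C2=NOC(c3ccc(C)cc3)C2S(=O)(=O)CC2=NCCO2)cc1` and the unmeasured compound 4 `COc1ccc(C2=NOC(c3ccc(C)cc3)C2S(=O)(=O)CC2=NCCS2)cc1` share another. The difference between the two cores is not broken down here.

In a functional assay, read by Griess assay, with a stated time of 150 min, tested at 50 ug/mL (on this read-out higher numbers stand for a stronger effect at the one concentration tested and lower numbers for a weaker effect), compound 3 gives 45.9%. Compound 1 gives 43.1% in this assay. The change from compound 3 to compound 1 is a group of 5 heavy atoms (3 carbon, 1 nitrogen, 1 sulfur; one five-membered non-aromatic ring with 2 hetero atoms) in place of a group of 5 heavy atoms (3 carbon, 1 nitrogen, 1 oxygen; one five-membered non-aromatic ring with 2 hetero atoms), on a saturated chain carbon bound to a sulfonyl sulfur; it made a number 2.8 percentage points lower from compound 3 to compound 1 (within the scatter). Compound 2 gives 61.9% in this assay; its distances to compound 3 and to compound 1 are both beyond the scatter, so compound 2 stands highest of the three measured.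

Compound 4 carries the same kind of change on the core of compound 2: a group of 5 heavy atoms (3 carbon, 1 nitrogen, 1 sulfur; one five-membered non-aromatic ring with 2 hetero atoms) in place of a group of 5 heavy atoms (3 carbon, 1 nitrogen, 1 oxygen; one five-membered non-aromatic ring with 2 hetero atoms), on a saturated chain carbon bound to a sulfonyl sulfur. The place is described in the same words for both pairs. Among the compounds here this exchange occurs twice, once measured and once not.

Going by the values given here, for compound 4 the expected step is a number 2.9 percentage points lower from compound 2 to compound 4 (within the scatter), set beside the measured a number 2.8 percentage points lower from compound 3 to compound 1 (within the scatter); this rests on the single measured pair, in which compound 3 and compound 1 sit within the scatter of each other. Compound 4 is therefore expected to give about 59% in this assay. Among the compounds with values here, the expected range for compound 4 runs from 46% to 72%, wide because a number 2.8 percentage points lower from compound 3 to compound 1 (within the scatter) is the only measured step of this kind.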

Compound 4, a percentage reported as activity, at one concentration (the size of the read-out at that concentration, not a potency): 48.6%
For compound 4 the middle estimate is 10.4 percentage points above the measured one; the range from low to high includes it.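

On the core of compound 2, in this assay, exchanging the oxygen-containing five-membered ring for the sulfur-containing one gives a number 13.3 percentage points lower from compound 2 to compound 4 (beyond the scatter), and this step does not separate from the one measured on the other core: the same change on two cores in this assay, a number 2.8 percentage points lower (within the scatter) from compound 3 to compound 1 and a number 13.3 percentage points lower (beyond the scatter) from compound 2 to compound 4, 10.5 percentage points apart, within the scatter of two such steps

Going by these compounds alone, the two pairs are therefore compatible with a single step that carries from one core to the other, even though only the step on the core of compound 2 stands beyond the scatter on its own. They do not show that the step is the same on both cores, nor that the core changes its size, since two pairs at one concentration can settle neither reading and give no potency.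

The compounds shown leave open how the read-out responds to a group of another kind on a saturated chain carbon bound to a sulfonyl sulfur, such as an amine, a carboxylic acid or a longer chain. They also leave open which part of the difference between the two cores goes with the higher number of compound 2, as that difference is not broken down into single changes here.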